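Swapping the Outer Heteroaryl Ring at the Bombesin Receptor

The source may hold more compounds than are shown below. What is called first, only, known or untested is meant among the compounds shown, and "the series" means these compounds.

Two close relatives share one core and differ only in the small aromatic ring at its far end. Compound 1 `CCC(C)(C)Cc1c[nH]c(CCc2ccc(-c3csnn3)cc2)n1` carries a 1,2,3-thiadiazol-4-yl ring and in a functional assay on HEK293 cells for agonist activity at Bombesin receptor subtype-3 (Mus musculus), read by luminescence and calcium flux, with a stated time of 10 min (on this read-out lower numbers stand for an effect already at smaller amounts and higher numbers for an effect only at larger amounts of compound), compound 1 gives 109 nM. Compound 2 `CCC(C)(C)Cc1c[nH]c(CCc2ccc(-c3cnsc3)cc2)n1` carries a 1,2-thiazol-4-yl ring instead, and in this assay compound 2 gives 119 nM. The step of a 1.1-fold higher number from compound 1 to compound 2 (0.04 log units; within the scatter) shows the two within the scatter of each other, so compound 2 has the higher of the two numbers but by a margin that means nothing.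

Compound 3 `CCC(C)(C)Cc1c[nH]c(CCc2ccc(-c3cccnc3)cc2)n1` goes one step further: pyridin-3-yl in place of 1,2-thiazol-4-yl on an aromatic carbon. Within the data shown here, the only measured step that bears on a change of this outer ring is a 1.1-fold higher number from compound 1 to compound 2 (0.04 log units; within the scatter), and it was within the scatter. Compound 3 is therefore expected to show no step beyond the scatter, a 1.1-fold higher number from compound 2 to compound 3 (0.04 log units; within the scatter), with compound 3 estimated at 130 nM in this assay, in a range from 50 nM to 350 nM.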

Compound 3, half-maximal effective concentration: 97 nM
For compound 3 the middle estimate is 1.3-fold (0.13 log units) above the measured one; measured number inside the range.
By their numbers in this assay, from the lowest: compounds 3, 1 and 2 (each within the scatter of the next).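

Among these compounds, until now, only one five-membered aromatic ring had been exchanged for another at this position, para to a large group. Here a six-membered aromatic ring with a single hetero atom and no sulfur enters, and in this assay the change gives a 1.2-fold lower number from compound 2 to compound 3 (0.09 log units; within the scatter) and a 1.1-fold lower number from compound 1 to compound 3 (0.05 log units; within the scatter). Neither ring size nor the loss of sulfur therefore moves the number beyond the scatter among these three compounds. No supporting data are available to explain why these rings read alike.

Going by these compounds, whether an amine, a carboxylic acid or a longer alkyl chain at this position would fit the same picture remains open. On these data alone, all three compounds also share one core, so it is equally open whether these swaps would behave alike on a different core.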